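Bromine Shifted Around the Ring on a Cyclopropane Diamide

A few compounds are considered here, and "the series" means these few. Any claim that something is new, unique, unknown or untested is made for them only; others in the source may bear on it.

Measured so far:
compound 1 `CN(C)C(=O)c1cc2cnc(Nc3ccc(NC(=O)C4(C(=O)Nc5ccc(F)cc5)CC4)cc3F)nc2n1C1CCCC1`, 6.6%
compound 2 `CN(C)C(=O)c1cc2cnc(Nc3ccc(NC(=O)C4(C(=O)Nc5ccc(Br)cc5)CC4)cc3)nc2n1C1CCCC1`, 23.2%
compound 3 `CN(C)C(=O)c1cc2cnc(Nc3ccc(NC(=O)C4(C(=O)Nc5ccc(Cl)c(C(F)(F)F)c5)CC4)cc3)nc2n1C1CCCC1`, -11.2%

In a functional assay on SiHa cells (Homo sapiens) for inhibition, read by CCK-8 assay, with a stated time of 72 h, tested at 1 uM (on this read-out higher numbers stand for more inhibition of growth at the one concentration tested and lower numbers for less inhibition of growth), compound 2 gives the highest of the three numbers; compound 1 sits lower by a step beyond the scatter, and compound 3 lies lowest, with a number 34.4 percentage points lower from compound 2 to compound 3 (beyond the scatter). All three numbers are modest.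

Compound 4 `CN(C)C(=O)c1cc2cnc(Nc3ccc(NC(=O)C4(C(=O)Nc5cccc(Br)c5)CC4)cc3)nc2n1C1CCCC1` has not yet been measured. It differs from compound 2 by 3-bromophenyl in place of 4-bromophenyl on an amide-type nitrogen. Going by the values given here, no measured step changes only the position of the bromine, so no step bears on it directly. Among the compounds with values here, the one step that alters the same ring, a number 34.4 percentage points lower from compound 2 to compound 3 (beyond the scatter), changed the halogen and added a trifluoromethyl group at once; it shows that changes on this ring can move the number a long way downward, but it cannot be split into its parts. With no closer guide, a step from compound 2 to compound 4 is expected to be small or downward, not upward. Compound 4 is therefore estimated at 12%, in a range from -10% to 30%, which is expected to mean a number 11.2 percentage points lower from compound 2 to compound 4 (beyond the scatter).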

Compound 4, percent growth inhibition at one concentration: 13.9%
Estimate against measurement, compound 4: 1.9 percentage points below; measured number inside the range.
By their numbers in this assay, from the lowest: compound 3; then compounds 1, 4 and 2 (each within the scatter of the next, the first and the last beyond it).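

Moving the bromine on the ring attached to the amide-type nitrogen gives, in this assay, a number 9.3 percentage points lower from compound 2 to compound 4 (within the scatter), so 4-bromophenyl and 3-bromophenyl cannot be told apart on this read-out. Exchanging 4-chloro-3-(trifluoromethyl)phenyl for 3-bromophenyl gives a number 25.1 percentage points higher from compound 3 to compound 4 (beyond the scatter), so among these compounds, replacing the group on this ring matters more than moving the bromine. No supporting measurement is available to explain either step.

The compounds shown leave open whether chlorine alone or trifluoromethyl alone accounts for the low number of compound 3. They also leave open what a methoxy group, an amine or a carboxylic acid would do on this ring in place of the bromine.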